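Adding a Carboxy Group to the Ethoxy Chain of Compound 2

A few compounds are considered here, and "the series" means these few. Any claim that something is new, unique, unknown or untested is made for them only; others in the source may bear on it.

Compound 1 `O=c1c(-c2ccc(O)cc2)coc2cc(OCCOCCOCCO)ccc12` gives 40 nM in an assay (Cricetulus griseus) for inhibition of aldehyde dehydrogenase, mitochondrial (Homo sapiens); on this read-out lower numbers stand for stronger inhibition and higher numbers for weaker inhibition.
Compound 2 `CCOc1ccc2c(=O)c(-c3ccc(O)cc3)coc2c1` gives 80 nM in this assay.

Going by the values given here, compound 2 holds the higher of the two numbers, its only neighbour being the step of a 2.0-fold higher number from compound 1 to compound 2 (0.30 log units; within the scatter). Compound 3 `CC(Oc1ccc2c(=O)c(-c3ccc(O)cc3)coc2c1)C(=O)O` differs from compound 2 by carboxy in place of hydrogen on a saturated chain carbon bound to an oxygen on an aromatic ring and a saturated chain carbon. Among the compounds with values here, no measured step involves a carboxy group; the single step of a 2.0-fold higher number from compound 1 to compound 2 (0.30 log units; within the scatter) shows only that reshaping the chain moved the number modestly. A small change beyond the scatter, toward weaker inhibition, is therefore the working expectation: a 1.9-fold higher number from compound 2 to compound 3 (0.27 log units; within the scatter). Compound 3 is estimated at 150 nM, with a range from 40 nM to 600 nM.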

Compound 3, half-maximal inhibitory concentration: 2500 nM
The estimate for compound 3 lay 17-fold (1.22 log units) below the measured number; measured number above the stated range.
By their numbers in this assay, from the lowest: compounds 1 and 2 (each within the scatter of the next); then compound 3.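

On the saturated chain carbon bound to an oxygen on an aromatic ring, carboxy in place of hydrogen proved far from neutral: the change gave a 31-fold higher number from compound 2 to compound 3 (1.49 log units; beyond the scatter) and so exceeded the scatter, which the earlier chain change did not. Replacing the 2-(2-(2-hydroxyethoxy)ethoxy)ethyl chain with 1-carboxyethyl gave a 63-fold higher number from compound 1 to compound 3 (1.80 log units; beyond the scatter) and widened the gap further. No available evidence accounts for this loss of inhibition.

Still open, going by these compounds, is whether a methyl ester or primary amide at this carbon would behave like the carboxylic acid. On these data alone, it is also open whether a carboxylic acid at the end of a longer chain would weaken inhibition as much.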